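The source may report more compounds than this note shows. Statements on the series, on what has been measured and on what is new or still open speak of the compounds shown alone.

Measured so far, in a functional assay on MDA-MB-468 cells (Homo sapiens) for antiproliferative activity, read by MTT assay, with a stated time of 72 h; a lower number here means a stronger inhibitor, a higher number a weaker inhibitor:

Compound 1 `CCOC(=O)c1oc2ccc(NS(=O)(=O)c3cccc(C)c3)cc2c1C` gives 25300 nM.
Compound 2 `CCOC(=O)c1oc2ccc(NS(=O)(=O)c3ccccc3C(F)(F)F)cc2c1C` gives 74900 nM.

Both compounds share the same core and differ only in the group on the outer benzene ring of the sulfonamide. Of the two, compound 2 stands at the higher number, and its gap to compound 1 is beyond the scatter, so compound 2 is the weaker inhibitor here.

Compound 3 `CCOC(=O)c1oc2ccc(NS(=O)(=O)c3ccccc3[N+](=O)[O-])cc2c1C` is the next step from compound 2: nitro in place of trifluoromethyl on an aromatic carbon, ortho to a large group. Within the data shown here, no step between two measured compounds shows how such an exchange moves this assay, so the expected change is small, in either direction, and no larger than the scatter. For compound 3 the estimate is 60000 nM, with a range from 20000 nM to 150000 nM, which means a step of a 1.2-fold lower number from compound 2 to compound 3 (0.10 log units; within the scatter) expected to stay within the scatter.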

Compound 3, half-maximal inhibitory concentration: 96900 nM
Compound 3: the middle estimate sits 1.6-fold (0.21 log units) below what was measured; the range from low to high includes it.
By their numbers in this assay, from the lowest: compound 1; then compounds 2 and 3 (each within the scatter of the next).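

In this assay, nitro in place of trifluoromethyl on this aromatic carbon, ortho to a large group, gives a 1.3-fold higher number from compound 2 to compound 3 (0.11 log units; within the scatter), so this exchange does not separate the two groups in this assay. Among these compounds, this is the first direct reading at this position, and it shows that two different groups can give numbers within the scatter of each other there. By contrast, 2-nitrophenyl in place of 3-methylphenyl on the sulfonyl sulfur gives a 3.8-fold higher number from compound 1 to compound 3 (0.58 log units; beyond the scatter), but this step changes both the group and where it sits, so it cannot be assigned to either change alone.

On these data alone, it remains open whether an amine or a carboxylic acid on the same aromatic carbon would shift the number beyond the scatter, and how nitro would behave where compound 1 carries its methyl. Nothing available here explains these results.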